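Swapping the thiophene for a furan on a bicyclic amine

The source may report more compounds than this note shows. Statements on the series, on what has been measured and on what is new or still open speak of the compounds shown alone.

The series shares a bicyclic amine core carrying a five-membered aromatic ring on the carbon bound to the nitrogen: compound 1 `CCc1ccsc1CN[C@@H]1C[C@H]2C[C@@H]([C@H]1C)C2(C)C`, compound 2 `C[C@H]1[C@H](NCc2ccsc2)C[C@H]2C[C@@H]1C2(C)C` and compound 3 `C[C@H]1[C@H](NCc2cc(-c3ccccc3)cs2)C[C@H]2C[C@@H]1C2(C)C`. In an ADME assay on MDCK cells (Canis lupus familiaris) for cytotoxicity, read by microscopy, with a stated time of 48 h (on this read-out higher numbers stand for lower toxicity in this test and lower numbers for higher toxicity in this test), compound 2 gives 50000 nM. Compound 1 gives 25000 nM in this assay, a difference from compound 2 that sits within the usual scatter. Compound 3 gives 5000 nM, a gap beyond the scatter, so compound 2 and compound 3 differ in earnest. Compound 4 `C[C@H]1[C@H](NCc2ccco2)C[C@H]2C[C@@H]1C2(C)C` is not yet measured; it differs from compound 2 by furan-2-yl in place of thiophen-3-yl on a saturated chain carbon bound to an amine nitrogen. Among the compounds with values here, with no measured step for such a swap, the step of a 1.3-fold lower number from compound 2 to compound 4 (0.10 log units; within the scatter) is expected to stay within the scatter. Compound 4 is estimated at 40000 nM, with a range from 15000 nM to 100000 nM.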

Compound 4, minimum cytotoxic concentration: 50000 nM
The estimate for compound 4 lay 1.3-fold (0.10 log units) below the measured number; measured number inside the range.
By their numbers in this assay, from the lowest: compound 3; then compounds 1, 2 and 4 (each within the scatter of the next).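

In this assay, within the data shown here, the swap of furan-2-yl in place of thiophen-3-yl on a saturated chain carbon bound to an amine nitrogen gives no change at the digits printed from compound 2 to compound 4 (within the scatter) and supplies the first measured step at this position. At this place, on this core, the test therefore tolerates the exchange of one five-membered aromatic ring for the other without a change beyond the scatter. No measured property is available to explain this result.

As far as these compounds go, whether a pyridin-3-yl ring or a butyl chain at this place would also stay within the scatter remains open. So does whether the same swap would hold on the substituted thiophenes of compound 1 and compound 3.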